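The compounds below may be only part of what the source reports. "The series", "measured", "known", "first", "only" and "open" are said of these compounds alone.

Measured so far:
- compound 1 `CCC1C(=O)N(C)c2cnc(Nc3ccc(S(=O)(=O)NCC(C)C)cc3)nc2N1c1ccn(C)n1`: 5310 nM
- compound 2 `CCCNS(=O)(=O)c1ccc(Nc2ncc3c(n2)N(C2CCCC2)[C@H](CC)C(=O)N3C)cc1`: 459 nM
- compound 3 `CC[C@@H]1C(=O)N(C)c2cnc(-n3ccc4cc(F)ccc43)nc2N1C1CCCC1`: "not active" (no number reported)

All three were tested in a functional assay on HeLa cells (Homo sapiens) for antiproliferative activity, read by CCK-8 assay, with a stated time of 72 h; a higher number here means a weaker inhibitor of growth, a lower number a stronger inhibitor of growth. There, compound 3 is reported as "not active" (no number reported) and has no number, so it cannot be placed on a scale with the other two.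

Compound 4 `CC[C@@H]1C(=O)N(C)c2cnc(-n3ccc4cc(C(=O)NCC(C)C)ccc43)nc2N1C1CCCC1` keeps the rest of compound 3 and carries isobutylcarbamoyl in place of fluoro on an aromatic carbon. Within the data shown here, no measured step shows this change. The expectation in this assay is a move towards stronger growth inhibition, from no number to a measurable value, though the size of that step cannot be given and a second "not active" result remains possible. This rests only on the isobutyl chain that compound 4 shares with compound 1, which gives 5310 nM, and on the numbers reached by compound 2, which gives 459 nM.

For compound 4 the estimated value is 3000 nM, with an expected range of 600 nM to 15000 nM.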

Compound 4, concentration for 50% growth inhibition: 3280 nM
Compound 4: middle estimate off by 1.1-fold (0.04 log units), on the low side, and the stated range covers the measured number.
By their numbers in this assay, from the lowest: compound 2; then compounds 4 and 1 (each within the scatter of the next).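

In this assay, among these compounds, compound 3 has no number, so no step from it to compound 4 can be read. The compounds shown leave open how much of the activity of compound 4 comes from isobutylcarbamoyl itself. No measured evidence bears on this result.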